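The source may hold more compounds than are shown below. What is called first, only, known or untested is meant among the compounds shown, and "the series" means these compounds.

Measured in an ADME assay on BHK-21 cells (Mesocricetus auratus) for cytotoxicity, with a stated time of 3 days; a higher number here means that more compound is tolerated, a lower number that less compound is tolerated:
- compound 1 `O=C(CCSc1nnc(-c2ccncc2)s1)Nc1ccccc1Cl` gives > 50000 nM (a limit of the assay)
- compound 2 `O=C(CCSc1nnc(-c2ccncc2)s1)NCc1ccccc1` gives 18700 nM

Compound 1 stands at a limit of this assay and not at a number, as the limit of > 50000 nM in this assay, at which 1 of the 2 values shown sits, records. Compound 3 `CC(CSc1nnc(-c2ccncc2)s1)C(=O)Nc1ccccc1Cl` differs from it by methyl in place of hydrogen on a saturated chain carbon bound to a carbonyl carbon and a saturated chain carbon, a methyl in place of hydrogen on a saturated chain carbon bound to a carbonyl carbon and a saturated chain carbon. Among the compounds with values here, the only measured step, an at least 2.6-fold lower number from compound 1 to compound 2 (0.42 log units; beyond the scatter), concerns the group on an amide-type nitrogen, so it bears only indirectly on this change. It does show that a number can be reached within this small set. No step beyond the scatter is therefore expected in this assay, and compound 3 may again be reported only as a limit. The estimated step is a number no higher from compound 1 to compound 3 (the limit leaves the size open). Compound 3 is expected at 50000 nM, with an estimated range of 20000 nM to 100000 nM.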

Compound 3, half-maximal cytotoxic concentration: > 50000 nM
Compound 3 gave a limit, no number (the forecaster's own chance of this, stated with the estimate: 55%); the middle value sits exactly at the limit.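

In this assay, compound 1 and compound 3 both stand at a limit and not at a number, so no step can be read between them: the limit of > 50000 nM in this assay, at which 2 of the 3 values shown sit.

The compounds shown leave open whether methyl in place of hydrogen at this place changes the number in this assay at all.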